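A few compounds are considered here, and "the series" means these few. Any claim that something is new, unique, unknown or untested is made for them only; others in the source may bear on it.

Measured in a functional assay on DLD-1 cells (Homo sapiens) for cytotoxicity, read by MTT assay, with a stated time of 72 h; a higher number here means a weaker inhibitor, a lower number a stronger inhibitor:
- compound 1 `Cc1c(/N=C/c2ccc(N(C)C)cc2)c(=O)n(-c2ccccc2)n1C`: 871000000 nM
- compound 2 `Cc1c(/N=C/c2cccc(O)c2)c(=O)n(-c2ccccc2)n1C`: 372000000 nM
- compound 3 `COc1cc(/C=N/c2c(C)n(C)n(-c3ccccc3)c2=O)ccc1O`: 759000000 nM

Compound 2 gives the lowest number of the three. The nearest is compound 3, whose higher number lies beyond the usual scatter; compound 1 stands furthest, also beyond the scatter. Within the data shown here, no pair among the measured compounds differs in a single place, so no measured step is available.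

Compound 4 `Cc1c(/N=C/c2ccccc2)c(=O)n(-c2ccccc2)n1C` is the next compound for this assay. It differs from compound 2 in one place: hydrogen in place of hydroxy on an aromatic carbon. Without a measured step of this kind, only a small change is expected, if any, most likely toward a slightly higher number, not clearly beyond the scatter.

For compound 4, the expected value in this assay is 500000000 nM, with a range of 200000000 nM to 1200000000 nM. The step expected is a 1.3-fold higher number from compound 2 to compound 4 (0.13 log units; within the scatter).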

Compound 4, half-maximal inhibitory concentration: 933000000 nM
Compound 4: middle estimate off by 1.9-fold (0.27 log units), on the low side; low and high end bracket the measured number.
By their numbers in this assay, from the lowest: compound 2; then compounds 3, 1 and 4 (each within the scatter of the next).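

In this assay, among these compounds, the first single-place step at this position gives a 2.5-fold higher number from compound 2 to compound 4 (0.40 log units; beyond the scatter) when hydroxy gives way to hydrogen, so the 3-hydroxyphenyl group of compound 2 separates from plain phenyl by a modest margin. Hydrogen in place of dimethylamino on an aromatic carbon gives a 1.1-fold higher number from compound 1 to compound 4 (0.03 log units; within the scatter) and so does not separate those two compounds. Nothing measured here accounts for either step.

From the compounds shown here alone, whether an amine or a carboxylic acid at this position would match hydroxy remains open. Also open, going by these compounds, is whether the step from hydroxy to hydrogen would hold on a different core.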